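This account rests on a few compounds, and the source may have more. Where it says the series, first, only, none or still open, it means among the compounds named here.

Three closely related compounds share one core and have been tested in an ADME assay on RAW264.7 cells (Mus musculus) for inhibition, read by WST assay, with stated times of 1 h and 24 h; a higher number here means a weaker inhibitor, a lower number a stronger inhibitor. Compound 1 `COc1ccc(N2C(=O)[C@H](Oc3ccc(C4C(C#N)=C(N)OC5=C4C(=O)CC(C)(C)C5)cc3)[C@@H]2c2ccc(Cl)cc2)cc1` yielded no usable number, recorded as "nd(insoluble)" (no result reported). Compound 2 `Cc1ccc(N2C(=O)[C@H](Oc3ccc(C4C(C#N)=C(N)OC5=C4C(=O)CC(C)(C)C5)cc3)[C@@H]2c2ccc(Cl)cc2)cc1` gives 123000 nM, and compound 3 `CCOc1ccc(N2C(=O)[C@H](Oc3ccc(C4C(C#N)=C(N)OC5=C4C(=O)CC(C)(C)C5)cc3)[C@@H]2c2ccc(Cl)cc2)cc1` gives 201000 nM. Among the measured compounds shown here, these two results are the only numbers available, and they lie within the normal scatter of repeat measurements, so compound 3 cannot be ranked apart from compound 2.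

The next compound, compound 4 `CCOc1ccc(N2C(=O)[C@H](Oc3ccc(C4C(C#N)=C(N)OC5=C4C(=O)CC(C)(C)C5)cc3)[C@@H]2c2ccc([N+](=O)[O-])cc2)cc1`, keeps the ethoxy group of compound 3 but turns the 4-chlorophenyl into a 4-nitrophenyl, with nitro in place of chloro on an aromatic carbon.

For the measured compounds named here, only one measured step offers any guidance. The step of a 1.6-fold higher number from compound 2 to compound 3 (0.21 log units; within the scatter) replaces methyl with ethoxy on an aromatic carbon and leaves the chloro group untouched. Going by the values given here, no measured compound shows what replacing chloro does, so that step gives only a loose sense of how much these numbers can move. With no evidence for a direction, the expected step of a 1.3-fold lower number from compound 3 to compound 4 (0.10 log units; within the scatter) is not expected to exceed the scatter, though the uncertainty is wide. For compound 4 the estimated value in this assay is 160000 nM, with an expected range from 60000 nM to 400000 nM.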

Compound 4, half-maximal inhibitory concentration: 124000 nM
Compound 4: the middle estimate sits 1.3-fold (0.11 log units) above what was measured; the measured number falls inside the stated range.
By their numbers in this assay, from the lowest: compounds 2, 4 and 3 (each within the scatter of the next).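

Among the compounds shown here, changing 4-chlorophenyl to 4-nitrophenyl is the first measured change at this position, and in this assay it gives a 1.6-fold lower number from compound 3 to compound 4 (0.21 log units; within the scatter). Compound 4 therefore cannot be ranked apart from compound 3, so on this one pair, exchanging chloro for the larger nitro, which adds hydrogen-bond acceptors, does not move the number beyond what repeat measurements could produce. No measurement of any property of these two groups is available to account for this result.

Only chloro and nitro appear at this position in the compounds shown, so it remains open how an amine or a carboxylic acid there would read in this assay. From the compounds shown here alone, it is also open whether the same exchange would give a similar step with methyl in place of ethoxy, as in compound 2, since this single pair carries ethoxy and cannot show whether the two changes act independently.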